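A few compounds are considered here, and "the series" means these few. Any claim that something is new, unique, unknown or untested is made for them only; others in the source may bear on it.

Measured in a functional assay on BXPC-3 cells (Homo sapiens) for antiproliferative activity, read by MTT assay, with a stated time of 24 h; a higher number here means a weaker inhibitor, a lower number a stronger inhibitor:
Compound 1 `CCn1c(C(=O)NCCC(=O)OC)ccc1C(CC)(CC)c1ccc(OCS(=O)(=O)c2ccccc2)c(C)c1`: > 50000 nM. This value is a limit.
Compound 2 `CCn1c(C(=O)NCCO)ccc1C(CC)(CC)c1ccc(OCS(=O)(=O)c2ccccc2)c(C)c1`: 19900 nM.
Compound 3 `CCn1c(C(=O)N[C@H](CO)C(C)C)ccc1C(CC)(CC)c1ccc(OCS(=O)(=O)c2ccccc2)c(C)c1`: 7720 nM.

Compound 3, at 7720 nM, holds the lower of the two actual numbers in this assay, and the nearest is compound 2 at 19900 nM. The reading for compound 1 gives only a limit, so it cannot be ranked exactly.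

The next compound is compound 4 `CCn1c(C(=O)N[C@H](CO)CCO)ccc1C(CC)(CC)c1ccc(OCS(=O)(=O)c2ccccc2)c(C)c1`. It differs from compound 3 as follows: 2-hydroxyethyl in place of isopropyl on a saturated chain carbon bound to an amide-type nitrogen and a saturated chain carbon. In words, 2-hydroxyethyl stands in place of isopropyl on a saturated chain carbon bound to an amide-type nitrogen and a saturated chain carbon.

The closest measured change at that carbon is a 2.6-fold lower number from compound 2 to compound 3 (0.41 log units; beyond the scatter), with isopropyl in place of hydrogen. Compound 4 gives up that isopropyl, although a group of the same heavy-atom count takes its place. The other relevant change is an at least 2.5-fold lower number from compound 1 to compound 2 (0.40 log units; beyond the scatter), with hydroxy in place of methoxycarbonyl, but it starts from a limit and gives only a bound on its size. Neither change tests 2-hydroxyethyl directly, so the expectation is loose. A modest move toward a higher number in this assay is expected, and the estimated step is a 1.8-fold higher number from compound 3 to compound 4 (0.26 log units; within the scatter). The estimated value for compound 4 is 14000 nM, with an expected range from 5000 nM to 40000 nM.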

Compound 4, half-maximal inhibitory concentration: 15900 nM
Compound 4: middle estimate off by 1.1-fold (0.06 log units), on the low side, and the stated range covers the measured number.
By their numbers in this assay, from the lowest: compound 3; then compounds 4 and 2 (each within the scatter of the next). At a limit, above all of these: compound 1.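

Replacing isopropyl with 2-hydroxyethyl on the saturated chain carbon bound to an amide-type nitrogen and a saturated chain carbon gives a 2.1-fold higher number from compound 3 to compound 4 (0.31 log units; beyond the scatter) in this assay, so at this carbon the number depends on which group is present, even with an equal heavy-atom count. Measured against hydrogen at the same carbon, the 2-hydroxyethyl group gives a 1.3-fold lower number from compound 2 to compound 4 (0.10 log units; within the scatter), so compound 2 and compound 4 cannot be told apart, whereas isopropyl gave a 2.6-fold lower number from compound 2 to compound 3 (0.41 log units; beyond the scatter). Compound 1 stands only at a limit of the assay, so an at least 3.1-fold lower number from compound 1 to compound 4 (0.49 log units; beyond the scatter) is a bound and not a measured size: the limit of > 50000 nM in this assay, at which 1 of the 4 values shown sits.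

The compounds shown do not settle whether the lower number of compound 3 goes with the branched isopropyl shape or with the lack of a hydroxy group on that side chain, and a straight propyl chain or a 2-methoxyethyl group at this carbon would separate the two readings. As far as these compounds go, how a 2-aminoethyl group or a carboxylic acid on this side chain would read in this assay also stays open.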